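The source may report more compounds than this note shows. Statements on the series, on what has been measured and on what is new or still open speak of the compounds shown alone.

Compound 1 `CC(C)N(Cc1cccc(OCCCCCC(=O)O)c1)C(=O)c1ccc(-c2cccc(OCc3ccccc3)c2)cc1` gives > 26000 nM in an ADME assay on BJ cells (Homo sapiens) for cytotoxicity, read by CellTiter-Glo and resazurin assay, with a stated time of 72 h (on this read-out higher numbers stand for an effect only at larger amounts of compound and lower numbers for an effect already at smaller amounts), a limit of the assay and not a number.
Compound 2 `CC(C)N(Cc1cccc(OCCCCCC(=O)O)c1)C(=O)c1ccc(-c2cc3ccccc3n2S(=O)(=O)c2ccccc2)cc1` gives > 26000 nM, likewise a limit of the assay.
Compound 3 `CCOC(=O)CCCCCOc1cccc(CN(C(=O)c2ccc(-c3cnc(OC)nc3OC)cc2)C(C)C)c1` gives > 26000 nM, again a limit of the assay.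

All three values sit together at the same limit (the limit of > 26000 nM in this assay, at which 3 of the 3 values shown sit). Compound 3 therefore stands where compound 1 and compound 2 stand, and no order among the three can be read from these numbers. Compound 4 `CCOC(=O)CCCCCOc1cccc(CN(C(=O)c2ccc(-c3cccc(OCC)c3)cc2)C(C)C)c1` has not yet been measured in this assay. It differs from compound 3 in one place: 3-ethoxyphenyl in place of 2,4-dimethoxypyrimidin-5-yl on an aromatic carbon. Within the data shown here, no measured step between two of the compounds bears on this change. The step that the limit leaves unreadable from compound 3 to compound 4 is expected to stay within the scatter. Compound 4 is expected near 30000 nM, with a range from 15000 nM to 60000 nM, and most likely it will again be reported only as a limit.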

Compound 4, half-maximal effective concentration: > 22300 nM
Compound 4: a limit, no number (the forecaster's own chance of this, stated with the estimate: 85%); the middle value is on the limit's open side.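

Among these compounds, compound 3 and compound 4 are both reported only as limits of the assay, so no step between them can be read. The compounds shown leave open at what concentration any of them would show an effect in this assay.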